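Replacing the Amide Nitrogen Substituent of Compound 1

The source may report more compounds than this note shows. Statements on the series, on what has been measured and on what is new or still open speak of the compounds shown alone.

Measured compounds:
compound 1 `COc1ccc(C(=O)Nc2c(F)cccc2Cl)cc1OC1CCCC1` — 240 nM
compound 2 `COc1ccc(C(=O)Nc2ccccc2Cl)cc1OC` — 650 nM
compound 3 `COc1ccc(C(=O)Nc2ccccc2Cl)cc1OC(=O)C1CCCC1` — a limit of the assay, > 1000000 nM

In an assay on isolated protein for inhibition of phosphodiesterase 4A (Sus scrofa) (a lower number here means a stronger inhibitor, a higher number a weaker inhibitor), compound 1 gives 240 nM, the lowest of the two numbers shown. Compound 2 gives 650 nM, a higher number beyond the scatter. For compound 3 the assay reports only a limit, > 1000000 nM; this is the limit described as the limit of > 1000000 nM in this assay, at which 1 of the 3 values shown sits. Going by the values given here, the single measured step, an at least 1500-fold higher number from compound 2 to compound 3 (3.18 log units; beyond the scatter), concerns an oxygen on the aromatic ring and leaves the amide nitrogen untouched.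

Compound 4 `COc1ccc(C(=O)NN2C(Cl)=NC=CC2Cl)cc1OC1CCCC1` differs from compound 1 by a group of 8 heavy atoms (4 carbon, 2 nitrogen, 2 chlorine; one six-membered non-aromatic ring with 2 hetero atoms) in place of a group of 8 heavy atoms (6 carbon, 1 fluorine, 1 chlorine; one six-membered aromatic ring of carbon only), on an amide-type nitrogen. Among the compounds with values here, no measured step touches the amide nitrogen, so nothing among the three compounds tells how large this change will be or in which direction it will run. Within the data shown here, since compound 1 gives 240 nM and the new group has no precedent here, a weaker number is expected but with wide uncertainty. The estimate for compound 4 is 2000 nM, expected to lie between 300 nM and 20000 nM. The expected step is an 8.3-fold higher number from compound 1 to compound 4 (0.92 log units; beyond the scatter).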

Compound 4, half-maximal inhibitory concentration: 400 nM
Compound 4: the middle estimate sits 5.0-fold (0.70 log units) above what was measured; the measured number falls inside the stated range.
By their numbers in this assay, from the lowest: compounds 1, 4 and 2 (each within the scatter of the next, the first and the last beyond it). At a limit, above all of these: compound 3.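

In this assay, a 1.7-fold higher number from compound 1 to compound 4 (0.22 log units; within the scatter), so this exchange on the amide-type nitrogen leaves the reading within the scatter. The earlier compounds shown here said nothing about this position; compounds 1 and 4 now show that, in this pair, a six-membered aromatic ring of carbon only is not needed there for a reading in this range, and that a six-membered non-aromatic ring with 2 hetero atoms, which brings 2 hydrogen-bond acceptors and 2 double bonds outside aromatic rings, can stand in its place. Nothing measured here bears on why the two groups read alike.

The compounds shown leave open how a cyclohexyl ring, a pyridine ring or a plain ethyl chain on that nitrogen would read. They also leave open whether the two chlorine atoms of the entering group matter to its reading.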